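This account rests on a few compounds, and the source may have more. Where it says the series, first, only, none or still open, it means among the compounds named here.

Measured in a physicochemical assay for solubility, read by HPLC, with a stated time of 24 h; on this read-out higher numbers stand for higher solubility and lower numbers for lower solubility:
- compound 1 `O=C1O[C@@H](CO)CN1c1ccc(-n2cc(-c3ccccn3)cn2)c(F)c1`: 56400 nM
- compound 2 `COC(=O)CC1CCN(C[C@H]2CN(c3ccc(-n4cc(-c5ccccn5)cn4)c(F)c3)C(=O)O2)CC1`: 92100 nM
- compound 3 `O=C1CSC(=O)N1C[C@H]1CN(c2ccc(-n3cc(-c4ccccn4)cn3)c(F)c2)C(=O)O1`: 26900 nM

Compound 3 has the lowest number of the three, and compound 1 and compound 2 both lie beyond the scatter from it. Compound 4 `COC[C@H]1CN(c2ccc(-n3cc(-c4ccccn4)cn3)c(F)c2)C(=O)O1` keeps the shared core but differs from compound 3 in one place: methoxy in place of 2,4-dioxo-1,3-thiazolidin-3-yl on a saturated chain carbon bound to a saturated ring carbon. Methoxy stands in place of 2,4-dioxo-1,3-thiazolidin-3-yl on a saturated chain carbon bound to a saturated ring carbon.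

Among the measured compounds shown here, no measured step makes this exact change. The closest comparison has hydroxy at that place, and introducing the 2,4-dioxo-1,3-thiazolidin-3-yl group there gave a 2.1-fold lower number from compound 1 to compound 3 (0.32 log units; beyond the scatter). The step of a 3.4-fold lower number from compound 2 to compound 3 (0.53 log units; beyond the scatter) introduces the same group and points the same way. Both steps are modest, so removing that group is expected to give at most a small rise in this assay, possibly one that stays within the scatter. The expected change is a 1.6-fold higher number from compound 3 to compound 4 (0.19 log units; within the scatter). For compound 4 the estimated value is 42000 nM, with an expected range from 18000 nM to 95000 nM.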

Compound 4, solubility: 36200 nM
The estimate for compound 4 lay 1.2-fold (0.06 log units) above the measured number; measured number inside the range.
By their numbers in this assay, from the lowest: compounds 3, 4, 1 and 2 (each within the scatter of the next, the first and the last beyond it).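

In this assay, methoxy in place of 2,4-dioxo-1,3-thiazolidin-3-yl gives a 1.3-fold higher number from compound 3 to compound 4 (0.13 log units; within the scatter) and so stays within the scatter, which shows that this ring can be lost at this place without a clear shift in the number. Methyl in place of hydrogen on the oxygen of compound 1 gives a 1.6-fold lower number from compound 1 to compound 4 (0.19 log units; within the scatter) and also stays within the scatter, whereas methoxy in place of 4-((methoxycarbonyl)methyl)piperidin-1-yl gives a 2.5-fold lower number from compound 2 to compound 4 (0.41 log units; beyond the scatter) and is the only new step beyond it. Nothing available explains these differences in terms of any property of the groups.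

As far as these compounds go, it remains open how a plain piperidin-1-yl, without the ester side chain, would read at this place. From the compounds shown here alone, a carboxylic acid in place of the methyl ester of compound 2, or a longer ether chain such as ethoxy in place of methoxy, is equally open.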